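A few compounds are considered here, and "the series" means these few. Any claim that something is new, unique, unknown or untested is made for them only; others in the source may bear on it.

Measured compounds, each in a functional assay on NUGC-3 cells (Homo sapiens) for inhibition, read by sulforhodamine B assay, with a stated time of 48 h; on this read-out lower numbers stand for stronger inhibition of growth and higher numbers for weaker inhibition of growth:

Compound 1, `COc1ccc(NC(=O)c2nccc3ccccc23)cc1`: compound 1 gives > 10000 nM, which is a limit of this assay.
Compound 2, `O=C(Nc1ccccc1O)c1nccc2ccccc12`: compound 2 gives > 10000 nM, which is a limit of this assay.
Compound 3, `COc1ccccc1NC(=O)c1nccc2ccccc12`: compound 3 gives > 10000 nM, which is a limit of this assay.

All three measured compounds share the same amide-linked core, and the difference between compound 1 and compound 3, which have the same atoms joined differently, is not broken down here. Compound 3 and compound 2 differ in one place, (hydrogen in place of methyl on an oxygen on an aromatic ring). The step that the two limits leave unreadable from compound 3 to compound 2 cannot be read, since both compounds sit at the limit of > 10000 nM in this assay, at which 3 of the 3 values shown sit, so whatever this change does to growth inhibition stays hidden behind the limit.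

The unmeasured compound 4, `O=C(Nc1ccc(O)cc1)c1nccc2ccccc12`, arises from compound 1 by the same change, (hydrogen in place of methyl on an oxygen on an aromatic ring). It is the same change as that from compound 3 to compound 2, made at a place described in identical words. Among the measured compounds shown here, no measured step in this assay gives a direction for it, and the only evidence is the limit of > 10000 nM in this assay, at which 3 of the 3 values shown sit, at which every measured value sits. Against that background, the account expects the step that the limit leaves unreadable from compound 1 to compound 4 to stay small and compound 4 to remain weak in this assay. The estimate for compound 4 is therefore 15000 nM, with a range from 4000 nM to 60000 nM, and most likely this assay will again report only a limit for compound 4.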

Compound 4, concentration for 50% growth inhibition: > 10000 nM
Compound 4 ended at the assay's limit (the forecaster's own chance of this, stated with the estimate: 85%); the middle value is on the limit's open side.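

No new step can be read between compound 1 and compound 4, since both compounds stay at a limit in this assay: the limit of > 10000 nM in this assay, at which 4 of the 4 values shown sit. The compounds shown leave open whether methoxy to hydroxy changes growth inhibition at all, and which change to the shared core, if any, would give a readable value in this assay.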